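The compounds below may be only part of what the source reports. "The series", "measured", "known", "first", "only" and "open" are said of these compounds alone.

Measured so far:
- compound 1 `O=C(Nc1cccc(-n2cc(-c3ccncc3)c(-c3cc(O)cc(Cl)c3)n2)c1)Nc1ccc(Cl)c(Cl)c1`: 89%
- compound 2 `COc1cc(Cl)cc(-c2nn(-c3cccc(NC(=O)Nc4cc(C(F)(F)F)cc(C(F)(F)F)c4)c3)cc2-c2ccncc2)c1`: 37%

Among the compounds with values here, in a functional assay on SF-268 cells (Homo sapiens) for inhibition, read by sulforhodamine B assay, with a stated time of 48 h, tested at 1 uM (on this read-out lower numbers stand for a stronger effect and higher numbers for a weaker effect at the one concentration tested), compound 2 gives 37%, the lowest of the two numbers; the only neighbour is compound 1, whose value lies higher by a gap beyond the scatter. Compound 3 `COc1cc(Cl)cc(-c2nn(-c3cccc(NC(=O)Nc4cccc(C(F)(F)F)c4)c3)cc2-c2ccncc2)c1` is not yet measured. It differs from compound 2 in one place: hydrogen in place of trifluoromethyl on an aromatic carbon. Within the data shown here, no step between measured compounds shows the weight of such a change. Removing one of the two trifluoromethyl groups is expected to cost some of the effect of compound 2 37%, giving a moderate upward step a number 18 percentage points higher from compound 2 to compound 3 (beyond the scatter). Compound 3 is therefore estimated at 55%, within 30% to 85%.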

Compound 3, a percentage reported as activity, at one concentration (the size of the read-out at that concentration, not a potency): 79%
For compound 3 the middle estimate is 24 percentage points below the measured one, and the stated range covers the measured number.
By their numbers in this assay, from the lowest: compound 2; then compounds 3 and 1 (each within the scatter of the next).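

In this assay, hydrogen in place of trifluoromethyl on this aromatic carbon gives a number 42 percentage points higher from compound 2 to compound 3 (beyond the scatter), a large step. Even with the other trifluoromethyl group kept on the ring, much of the effect seen with compound 2 at the one concentration tested is lost with this single change. Nothing measured here accounts for the size of this step.

Going by these compounds, whether an amine, a nitrile or a carboxylic acid at this place would keep the effect of compound 2 remains open. Also open, on these data alone, is how hydrogen in place of the remaining trifluoromethyl group would read.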